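The source may report more compounds than this note shows. Statements on the series, on what has been measured and on what is new or still open speak of the compounds shown alone.

Measured so far: compound 1 `CCCN(CCC)c1nc(C(F)(F)F)ccc1CNC(=O)Nc1cccc2[nH]c(=O)ccc12` with 5.21 nM in an assay on HEK cells for antagonist activity at transient receptor potential cation channel subfamily V member 1 (Homo sapiens), read by FLIPR (a higher number here means a weaker inhibitor, a lower number a stronger inhibitor), and compound 2 `CC1CCC(c2nc(C(F)(F)F)ccc2CNC(=O)Nc2cccc3[nH]c(=O)ccc23)CC1` with 1.44 nM.

Compound 1 has the highest number of the two; its nearest neighbour is compound 2, reached by a 3.6-fold lower number from compound 1 to compound 2 (0.56 log units; beyond the scatter). Compound 3 `CC(C)c1cccc(-c2nc(C(F)(F)F)ccc2CNC(=O)Nc2cccc3[nH]c(=O)ccc23)c1` differs from compound 1 as follows: 3-isopropylphenyl in place of dipropylamino on an aromatic carbon. Within the data shown here, the one step that bears on this change is a 3.6-fold lower number from compound 1 to compound 2 (0.56 log units; beyond the scatter), which replaced the same dipropylamino group on the same aromatic carbon, and it was modest. A step of similar size and direction, a 2.6-fold lower number from compound 1 to compound 3 (0.42 log units; beyond the scatter), is therefore expected. Compound 3 is estimated at 2 nM, within 0.7 nM to 7 nM.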

Compound 3, half-maximal inhibitory concentration: 1.35 nM
The estimate for compound 3 lay 1.5-fold (0.17 log units) above the measured number; low and high end bracket the measured number.
By their numbers in this assay, from the lowest: compounds 3 and 2 (each within the scatter of the next); then compound 1.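

In this assay the change to 3-isopropylphenyl at this carbon next to the ring nitrogen gives a 3.9-fold lower number from compound 1 to compound 3 (0.59 log units; beyond the scatter) and so shows that the lower number seen with 4-methylcyclohexyl is not tied to that one group. Going from 4-methylcyclohexyl to 3-isopropylphenyl gives a 1.1-fold lower number from compound 2 to compound 3 (0.03 log units; within the scatter) so the two rings cannot be told apart here. No data given here explain these numbers. Still open, as far as these compounds go, is how an unsubstituted phenyl, a piperidine or a small methyl would fare at this carbon. From the compounds shown here alone, whether the isopropyl on the phenyl ring contributes also remains open.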